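The compounds below may be only part of what the source reports. "The series", "measured", "known", "first", "only" and "open" are said of these compounds alone.

Of the compounds shown here, three sharing one core have been tested in a functional assay on CHO cells with adenosine receptor A1 (Homo sapiens) as the target, read by cAMP accumulation and immunoassay, with a stated time of 6 min, tested at 10 uM; a higher number here means a weaker effect of the compound at the concentration tested, a lower number a stronger effect. Compound 1 `COc1ccc(N2CCN(Cc3csc(N)c3C(=O)c3ccc(Cl)cc3)CC2)cc1` gives -52%, the second highest of the three numbers. Compound 2 `Nc1scc(CN2CCN(c3ccc(Cl)c(C(F)(F)F)c3)CC2)c1C(=O)c1ccc(Cl)cc1` gives -60%, and the step of a number 8 percentage points lower from compound 1 to compound 2 (within the scatter) lies within the scatter. Compound 3 `Nc1scc(CN2CCN(c3ccccc3F)CC2)c1C(=O)c1ccc(Cl)cc1` gives -15%, and the step of a number 37 percentage points higher from compound 1 to compound 3 (beyond the scatter) stands well beyond the scatter, as does a number 45 percentage points higher from compound 2 to compound 3 (beyond the scatter).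

Compound 4 `Nc1scc(CN2CCN(c3ccccc3Cl)CC2)c1C(=O)c1ccc(Cl)cc1` has not yet been measured. It differs from compound 1 in one place: 2-chlorophenyl in place of 4-methoxyphenyl on an amine nitrogen in a ring. The measured step that bears most directly on this change is a number 37 percentage points higher from compound 1 to compound 3 (beyond the scatter), in which a 2-fluorophenyl also took the place of the 4-methoxyphenyl on the same amine nitrogen in the ring, and the number moved by a large amount. The step of a number 8 percentage points lower from compound 1 to compound 2 (within the scatter) concerns a different kind of group and adds little here. Within the data shown here, since the 2-chlorophenyl resembles the 2-fluorophenyl more than any other group seen so far, a shift of similar kind is expected for compound 4, a number 27 percentage points higher from compound 1 to compound 4 (beyond the scatter), though with only one comparable step the size remains uncertain. Compound 4 is therefore estimated to give about -25% in this assay, within a range from -50% to 0%.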

Compound 4, a percentage reported as activity, at one concentration (the size of the read-out at that concentration, not a potency): -18%
Estimate against measurement, compound 4: 7 percentage points below; the range from low to high includes it.
By their numbers in this assay, from the lowest: compounds 2 and 1 (each within the scatter of the next); then compounds 4 and 3 (each within the scatter of the next).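

The earlier compounds shown here gave only one large move away from the 4-methoxyphenyl, and the 2-chlorophenyl now adds a second, a number 34 percentage points higher from compound 1 to compound 4 (beyond the scatter); chloro in place of fluoro on the aromatic carbon gives a number 3 percentage points lower from compound 3 to compound 4 (within the scatter), so in this assay the large move is not limited to the fluoro compound. A chloro group in this aryl group does not settle the number by itself: compound 2 also carries one, in its 4-chloro-3-(trifluoromethyl)phenyl, and the change to 2-chlorophenyl gives a number 42 percentage points higher from compound 2 to compound 4 (beyond the scatter). Nothing measured on these compounds explains why the groups on this amine nitrogen give such different numbers.

On these data alone, with only four compounds, it remains open whether the number follows the halogen itself or the whole pattern of groups on the phenyl ring, since a plain phenyl group on the same nitrogen would be needed as a reference point. As far as these compounds go, it is also open how a bromo group on the ring, or a benzyl group in place of the phenyl, would read in this assay.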